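Isoflavone ether in place of ester: expectation before measurement

A few compounds are considered here, and "the series" means these few. Any claim that something is new, unique, unknown or untested is made for them only; others in the source may bear on it.

Compound 1, `COc1cccc(C(=O)Oc2ccc3c(=O)c(-c4cc(OC)c(OC)cc4OC)coc3c2)c1` — > 10000 nM
Compound 2, `COc1cc(OC)c(-c2coc3cc(OCC(=O)c4cccc(C(F)(F)F)c4)ccc3c2=O)cc1OC` — > 10000 nM

Both values come from a functional assay on U-251 cells (Homo sapiens) for antiproliferative activity, read by MTT assay, with a stated time of 24 h; a higher number here means a weaker inhibitor, a lower number a stronger inhibitor. For compound 1 the figure > 10000 nM is a limit of the assay, not a number. For compound 2 the figure > 10000 nM is likewise a limit. Compound 1 therefore stands at the weak end of what has been shown, since both values sit at the limit of > 10000 nM in this assay, at which 2 of the 2 values shown sit.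

The unmeasured compound 3, `COc1cc(OC)c(-c2coc3cc(OCc4ccccc4Br)ccc3c2=O)cc1OC`, differs from compound 1 in one place: 2-bromobenzyl in place of (3-methoxyphenyl)carbonyl on an oxygen on an aromatic ring. Within the data shown here, no step between measured compounds is available to gauge such a change; both measured compounds only share the limit. With nothing pointing toward gained potency, the step from compound 1 to compound 3 is expected to be small, a step that the limit leaves unreadable from compound 1 to compound 3, or none beyond the scatter. Compound 3 is estimated to give 15000 nM in this assay, within a range from 4000 nM to 60000 nM, with a fair chance that only a limit is reported again.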

Compound 3, half-maximal inhibitory concentration: > 10000 nM
Compound 3: only a limit was reported; the forecaster's own chance of this, stated with the estimate: 65%; the middle value is on the limit's open side.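

Compound 3, like compound 1 and compound 2, was reported only as a limit, so neither step to compound 3 can be read: the limit of > 10000 nM in this assay, at which 3 of the 3 values shown sit.

The compounds shown leave open how far the three lie apart past that limit, and whether any group at this place on the shared core gives a measurable value in this assay.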